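This account rests on a few compounds, and the source may have more. Where it says the series, first, only, none or still open, it means among the compounds named here.

Compound 1 `c1cc([C@H]2CC[C@]3(CC2)OOC2(O3)C3CC4CC(C3)CC2C4)ccc1OCCCNC1CCOCC1` — 10 mL.min-1.g-1
Compound 2 `N[C@H]1CC[C@H](Oc2ccc([C@H]3CC[C@]4(CC3)OOC3(O4)C4CC5CC(C4)CC3C5)cc2)CC1` — a limit of the assay, < 7 mL.min-1.g-1
Compound 3 `CC(C)(O)CNCCCOc1ccc([C@H]2CC[C@]3(CC2)OOC2(O3)C3CC4CC(C3)CC2C4)cc1` — 8 mL.min-1.g-1

All three share one core and differ only in the group carried on the oxygen on the aromatic ring. In an ADME assay on microsomes from liver (Homo sapiens) for metabolic stability, read by LC-MS, tested at 1 uM (on this read-out higher numbers stand for fast clearance and lower numbers for slow clearance), compound 1 gives 10 mL.min-1.g-1, the highest of the two numbers shown, while compound 3 sits nearest with a 1.3-fold lower number from compound 1 to compound 3 (0.10 log units; within the scatter). For compound 2 the assay reports no number but only a limit, < 7 mL.min-1.g-1; this is the limit of < 7 mL.min-1.g-1 in this assay, at which 1 of the 3 values shown sits.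

The unmeasured compound 4 `c1cc([C@H]2CC[C@]3(CC2)OOC2(O3)C3CC4CC(C3)CC2C4)ccc1OCCC1CCNCC1` differs from compound 1 by piperidin-4-yl in place of ((oxan-4-yl)amino)methyl on a saturated chain carbon, two bonds along the chain from an oxygen on an aromatic ring. Within the data shown here, two measured steps bear on this change: an at least 1.4-fold lower number from compound 1 to compound 2 (0.15 log units; that floor lies within the scatter) and a 1.3-fold lower number from compound 1 to compound 3 (0.10 log units; within the scatter). Both lie within the scatter, so across these compounds the group on that oxygen has not shifted the read-out in a way that can be told from noise. No step beyond the scatter is therefore expected here: a 1.3-fold lower number from compound 1 to compound 4 (0.10 log units; within the scatter). Compound 4 is estimated at 8 mL.min-1.g-1, between 4 mL.min-1.g-1 and 16 mL.min-1.g-1, with a fair chance that the assay again reports only a limit.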

Compound 4, intrinsic clearance in microsomes: < 7 mL.min-1.g-1
Compound 4 gave a limit, no number; the forecaster's own chance of this, stated with the estimate: 35%; middle value at least 1.1-fold (0.05 log units) from the limit.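

Compound 4 is the first of these compounds with piperidin-4-yl on the saturated chain carbon, two bonds along the chain from an oxygen on an aromatic ring, and in this assay the swap gives an at least 1.4-fold lower number from compound 1 to compound 4 (0.15 log units; that floor lies within the scatter) and an at least 1.1-fold lower number from compound 3 to compound 4 (0.05 log units; that floor lies within the scatter). Going by these compounds, both steps are only floors, so they show no change beyond the scatter, but their full size remains unknown. Compound 4 also gives a limit, the second compound to do so: the limit of < 7 mL.min-1.g-1 in this assay, at which 2 of the 4 values shown sit.

The step between compound 2 and compound 4 cannot be read, as both values are limits. On these data alone, it also remains open whether a longer chain between the oxygen and the piperidine, or a carboxylic acid on that ring, would move the read-out beyond the scatter.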